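The source may report more compounds than this note shows. Statements on the series, on what has been measured and on what is new or still open speak of the compounds shown alone.

Going by the values given here, in an assay on isolated protein for binding affinity to corticotropin-releasing factor receptor 1 (Homo sapiens) (a lower number here means a stronger inhibitor, a higher number a weaker inhibitor), compound 2 `CC(=O)/C(=N\c1ccc(Cl)cc1)NNc1ccccc1Cl` gives 3870 nM, the only plain number among the two measured compounds. Compound 1 `CC(=O)/C(=N\c1ccccc1Cl)NNc1ccccc1Cl` gives only a limit, > 10000 nM, in this assay. Among the compounds with values here, the single measured step, an at least 2.5-fold lower number from compound 1 to compound 2 (0.41 log units; beyond the scatter), shows that where the chlorine sits on this ring matters, with the limit of > 10000 nM in this assay, at which 1 of the 2 values shown sits, capping how much can be read from it. Compound 3 `CC(=O)/C(=N\c1cccc(C)c1)NNc1ccccc1Cl` carries 3-methylphenyl in place of 4-chlorophenyl on a double-bonded nitrogen. Within the data shown here, no measured step exchanges chlorine for methyl, so only a small shift is expected, a 1.4-fold higher number from compound 2 to compound 3 (0.15 log units; within the scatter), leaning toward weaker binding. Compound 3 is therefore estimated at 5500 nM, between 2000 nM and 15000 nM.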

Compound 3, inhibition constant: 115 nM
Estimate against measurement, compound 3: 48-fold (1.68 log units) above; the whole stated range lies above it.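

At this position on the double-bonded nitrogen, the ring substituent matters far more than the chlorine shift alone suggested: a 34-fold lower number from compound 2 to compound 3 (1.53 log units; beyond the scatter), even though 3-methylphenyl and 4-chlorophenyl have the same count of heavy atoms and the same ring. The widest gap shown is an at least 86-fold lower number from compound 1 to compound 3 (1.93 log units; beyond the scatter). That figure starts from a limit, the one compound 1 carries, so its true size stays open: the limit of > 10000 nM in this assay, at which 1 of the 3 values shown sits.

This change alters both the kind of group and its place on the ring, and the compounds shown do not separate the two. From the compounds shown here alone, how a methoxy group or an amine on this ring would fare also stays open.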